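A Hydroxyethyl Group Added to a Benzamide Series

This account rests on a few compounds, and the source may have more. Where it says the series, first, only, none or still open, it means among the compounds named here.

Measured compounds:
- Compound 1 `CC(=O)c1cc(C(=O)N[C@H](C)Cn2ccc(-c3cc(F)c(C#N)c(Cl)c3)n2)n[nH]1`: "not determined" (no result reported)
- Compound 2 `C[C@@H](Cn1ccc(-c2ccc(C#N)c(Cl)c2)n1)NC(=O)c1ccccc1`: "not determined" (no result reported)
- Compound 3 `CC(O)c1cccc(C(=O)N[C@@H](C)Cn2ccc(-c3ccc(C#N)c(Cl)c3)n2)c1`: 900 nM

Compound 2 carries a plain benzamide on the shared core. In a functional assay on VCaP cells (Homo sapiens) for antiproliferative activity, read by CCK-8 assay, with a stated time of 6 days (a lower number here means a stronger inhibitor, a higher number a weaker inhibitor), compound 2 gives "not determined" (no result reported), and compound 1 likewise gives "not determined" (no result reported), so compound 2 cannot be placed on any scale here. Going by the values given here, the only number in the set belongs to compound 3, which carries a 1-hydroxyethyl group on the benzamide ring: in this assay compound 3 gives 900 nM.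

The step to compound 4 `CC(O)c1ccc(C(=O)N[C@@H](C)Cn2ccc(-c3ccc(C#N)c(Cl)c3)n2)cc1` is 1-hydroxyethyl in place of hydrogen on an aromatic carbon. Compound 4 thus carries the same group as compound 3, though at a different place on that ring. With no number for compound 2, the size of this step cannot be measured; what can be said is that compound 4 is expected to land near compound 3 because compound 3 with the same group gives 900 nM. Compound 4 is expected to give about 700 nM in this assay, in a range from 150 nM to 3000 nM.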

Compound 4, half-maximal inhibitory concentration: 910 nM
The estimate for compound 4 lay 1.3-fold (0.11 log units) below the measured number, within the range that was stated.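

In this assay, going by these compounds alone, having the group as 4-(1-hydroxyethyl)phenyl instead of 3-(1-hydroxyethyl)phenyl gives a 1.0-fold higher number from compound 3 to compound 4 (0.00 log units; within the scatter), the one comparison here between two compounds that both have a number. For this pair, then, the read-out does not separate the two placements of the 1-hydroxyethyl group on the benzamide ring. No measurement on hand offers an explanation for this result.

Compound 2 stands at "not determined" (no result reported), and the step from hydrogen to 1-hydroxyethyl cannot be read, leaving open whether the group helps, harms or changes nothing compared with the plain benzamide. Going by these compounds, it also remains open whether a different group at this para position, such as an amine, a carboxylic acid or a longer chain, would give a different number.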